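Removing One Chloro From a Dichlorobenzyl Group

This account rests on a few compounds, and the source may have more. Where it says the series, first, only, none or still open, it means among the compounds named here.

Compound 1 `Cc1ccc(Cn2cc(CSC(=S)N3CCN(C(=O)OC(C)(C)C)CC3)nn2)cc1`: 19700 nM in a functional assay on MCF7 cells (Homo sapiens) for inhibition, read by MTT assay, with a stated time of 72 h; on this read-out higher numbers stand for weaker inhibition and lower numbers for stronger inhibition
Compound 2 `CC(C)(C)OC(=O)N1CCN(C(=S)SCc2cn(Cc3ccc(Cl)c(Cl)c3)nn2)CC1`: 19100 nM in this assay

Among the compounds with values here, compound 2 has the lowest of the two numbers measured so far, but its neighbour compound 1 sits so close that no order can be claimed: the step of a 1.0-fold lower number from compound 1 to compound 2 (0.01 log units; within the scatter) lies within the usual scatter.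

Compound 3 `CC(C)(C)OC(=O)N1CCN(C(=S)SCc2cn(Cc3ccc(Cl)cc3)nn2)CC1` is the next candidate. Compared with compound 2 the change is hydrogen in place of chloro on an aromatic carbon. Within the data shown here, the only measured step that touches this part of the molecule is a 1.0-fold lower number from compound 1 to compound 2 (0.01 log units; within the scatter), where the whole 4-methylphenyl was exchanged for 3,4-dichlorophenyl without any shift beyond the scatter. Taking one chloro away from that same ring is a smaller edit, so no movement beyond the scatter is expected in this assay either.

Compound 3 is therefore estimated at 19500 nM, with a plausible range from 9000 nM to 42000 nM. The expected step is a 1.0-fold higher number from compound 2 to compound 3 (0.01 log units; within the scatter).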

Compound 3, half-maximal inhibitory concentration: 2960 nM
For compound 3 the middle estimate is 6.6-fold (0.82 log units) above the measured one, outside the stated range (below it).
By their numbers in this assay, from the lowest: compound 3; then compounds 2 and 1 (each within the scatter of the next).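

In this assay, this position on the ring turns out to matter: hydrogen in place of chloro on an aromatic carbon, turning 3,4-dichlorobenzyl into 4-chlorobenzyl, gives a 6.5-fold lower number from compound 2 to compound 3 (0.81 log units; beyond the scatter) and so stronger inhibition. Chloro in place of methyl on an aromatic carbon gives a 6.7-fold lower number from compound 1 to compound 3 (0.82 log units; beyond the scatter) as well, so the earlier tie between 4-methylphenyl and 3,4-dichlorophenyl did not mean that this ring tolerates any change, since 4-chlorophenyl stands apart from both. Nothing here offers an explanation for these shifts.

As far as these compounds go, whether the lone chloro is itself required remains open, as a plain phenyl or a 4-fluorophenyl ring would test that. Also open, from the compounds shown here alone, is whether a 4-methoxyphenyl or 4-bromophenyl ring would fall nearer to compound 3 or to compound 2.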